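The source may hold more compounds than are shown below. What is called first, only, known or untested is meant among the compounds shown, and "the series" means these compounds.

Going by the values given here, compound 2 `COc1ccc(C(=O)/C(=C/c2ccccc2Cl)COC(=O)c2ccccc2)cc1` is the one member of the series with a number in a functional assay on A549 cells (Homo sapiens) for inhibition, read by XTT assay, with a stated time of 48 h; on this read-out higher numbers stand for weaker inhibition and lower numbers for stronger inhibition: compound 2 gives 20100 nM. Compound 1 `CCC(/C=C(\COC(=O)c1ccccc1)C(=O)c1ccc(OC)cc1)CC` gives only a limit in this assay, > 100000 nM, which is the limit of > 100000 nM in this assay, at which 1 of the 2 values shown sits. Among the compounds with values here, the step of an at least 4.9-fold lower number from compound 1 to compound 2 (0.69 log units; beyond the scatter) is the sole measured step, and it exchanges a substituent rather than geometry. Compound 3 `COc1ccc(C(=O)/C(=C\c2ccccc2Cl)COC(=O)c2ccccc2)cc1` differs from compound 2 only in configuration: the two compounds have the same atoms and bonds and differ only in configuration as drawn: 1 of 1 stereo elements differ; a double bond is drawn E in compound 2 and Z in compound 3. Within the data shown here, no measured step bears on a change of double-bond geometry, so no step beyond the scatter is expected, a 1.2-fold higher number from compound 2 to compound 3 (0.09 log units; within the scatter). Compound 3 is therefore expected at 25000 nM, within 8000 nM to 80000 nM.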

Compound 3, half-maximal inhibitory concentration: 52000 nM
Beside the measured number, compound 3's estimate is 2.1-fold (0.32 log units) below it; low and high end bracket the measured number.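

In this assay, double-bond geometry matters on its own at this position, with a 2.6-fold higher number from compound 2 to compound 3 (0.41 log units; beyond the scatter). Going by these compounds alone, the earlier step exchanged a substituent, so this is the first change that can be tied to configuration alone: the fact that compounds 2 and 3 differ only in the configuration as drawn. Among these two compounds, the double bond drawn E carries the lower number, and this holds only for the 2-chlorophenyl pair.

On these data alone, whether the E form also gives the lower number with pentan-3-yl on the double bond stays open. So does the effect of geometry with an amine or a carboxylic acid at the same place.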